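A few compounds are considered here, and "the series" means these few. Any claim that something is new, unique, unknown or untested is made for them only; others in the source may bear on it.

Compound 1 `N=C(S)CCN1N=C(c2cccs2)CCC1=O` — 58.5%
Compound 2 `CC/N=C(\S)CCn1nc(-c2ccccc2)ccc1=O` — 50.3%
Compound 3 `CC(Cn1ncccc1=S)C(=N)S` — -1%

In a functional assay on the whole organism (stomach) for inhibition, with Rattus norvegicus as the target, at a dose of 100 mg/kg by the intraduodenal route (on this read-out higher numbers stand for more inhibition at the one dose given (going by the name of the read-out) and lower numbers for less inhibition), compound 2 gives 50.3%. Among the three numbers this is the second highest. The nearest neighbour is compound 1, which gives 58.5%, a number that lies within the usual scatter of compound 2, so the two cannot be told apart. The furthest is compound 3, which gives -1%, a number well beyond the scatter and far lower.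

Compound 4 `N=C(S)Cn1nc(-c2ccccc2)ccc1=O` has not been measured. It differs from compound 2 in one place: a group of 3 heavy atoms (1 carbon, 1 nitrogen, 1 sulfur; no ring) in place of a group of 6 heavy atoms (4 carbon, 1 nitrogen, 1 sulfur; no ring), on a saturated chain carbon bound to an aromatic nitrogen. Among the compounds with values here, no step between measured compounds matches this change, so its size can only be expected, not read off. Compound 1 and compound 2 hold similar groups on their chains and sit close together, which suggests the change may matter little, yet compound 3, the only one with a shorter chain, sits far below. For compound 4 a modest fall in this assay is expected, with the step of a number 8.3 percentage points lower from compound 2 to compound 4 (within the scatter) estimated to stay near or just past the scatter. Compound 4 is therefore estimated at 42%, expected between 12% and 68%.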

Compound 4, a percentage reported as inhibition, in the whole organism at one dose (the size of the read-out at that dose, not a potency): 5.5%
Compound 4: middle estimate off by 36.5 percentage points, on the high side; the measured number lies below the stated range.
By their numbers in this assay, from the lowest: compounds 3 and 4 (each within the scatter of the next); then compounds 2 and 1 (each within the scatter of the next).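

Within the data shown here, the swap at this saturated chain carbon bound to an aromatic nitrogen is the first single change that can be read on its own, and in this assay it gives a number 44.8 percentage points lower from compound 2 to compound 4 (beyond the scatter). The group of 6 heavy atoms therefore cannot be exchanged for the group of 3 heavy atoms without losing most of the inhibition seen at this one dose, so this position is sensitive to the change. No measurement here explains why the inhibition falls.

As far as these compounds go, whether a longer chain, an amine or a carboxylic acid at this place would keep the inhibition remains open. It is also unknown whether the same swap on the core of compound 1 would produce a similar fall.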